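The compounds below may be only part of what the source reports. "The series", "measured", "known", "first", "only" and "open" are said of these compounds alone.

Four compounds built on a shared core are considered here: compound 1 `COC(=O)/C=C1\Nc2cc(Cl)ccc2OC1=O`, compound 2 `O=C1Oc2ccccc2N/C1=C\C(=O)c1cccs1`, compound 3 `COC(=O)/C=C1\Nc2cc(-c3ccccc3)ccc2OC1=O` and compound 4 `Cc1cccc(C(=O)/C=C2\Nc3ccccc3OC2=O)c1`, the last of which has not yet been tested.

Tolerability was measured in an ADME assay on Vero cells (Chlorocebus sabaeus) for cytotoxicity, read by MTT assay, with a stated time of 72 h; a higher number here means that more compound is tolerated, a lower number that less compound is tolerated. In this assay compound 1 gives 1630000 nM. For compound 2 the reading is not a number but a limit of the assay, > 1840000 nM, recorded as the limit of > 1840000 nM in this assay, at which 1 of the 3 values shown sits. For compound 3 the result in this assay is "not determined" (no result reported). Within the data shown here, compound 2 therefore stands only at a limit, alongside one further entry that carries no single number, so no step between two measured compounds is available to guide the next change.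

The change that leads from compound 2 to compound 4 is 3-methylphenyl in place of thiophen-2-yl on a carbonyl carbon. Among the measured compounds shown here, with no measured step to lean on, the expectation is a step no larger than the usual scatter in this assay, in no particular direction. Compound 4 is therefore estimated at 1700000 nM, with a range from 800000 nM to 2500000 nM, which corresponds to an expected step of an at least 1.0-fold lower number from compound 2 to compound 4 (0.03 log units; that floor lies within the scatter).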

Compound 4, half-maximal cytotoxic concentration: > 1790000 nM
Compound 4: no number, only a limit (the forecaster's own chance of this, stated with the estimate: 50%); middle value at least 1.0-fold (0.02 log units) from the limit.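

In this assay compound 4 gives > 1790000 nM, a limit of the assay and not a number. Compound 2 also stands only at a limit, so no step can be read from compound 2 to compound 4. Still open, going by these compounds, is whether 3-methylphenyl in place of thiophen-2-yl on a carbonyl carbon changes how much compound is tolerated.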